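The compounds below may be only part of what the source reports. "The series", "measured", "known", "first", "only" and "open" are said of these compounds alone.

In an ADME assay for permeability, using PAMPA, with a stated time of 3 h (on this read-out higher numbers stand for higher permeability and lower numbers for lower permeability), compound 1 (`O=C(Nc1ccc([N+](=O)[O-])cc1)c1cc(Cl)ccc1O`) gives 12.4 10^-6 cm/s, compound 2 (`O=C(Nc1cccc([N+](=O)[O-])c1)c1cc(Cl)ccc1O`) gives 19.5 10^-6 cm/s and compound 3 (`O=C(Nc1ccc(C(F)(F)F)cc1)c1cc(Cl)ccc1O`) gives 6.9 10^-6 cm/s. Compound 2 lies within the scatter of compound 1, while compound 3 sits lower than compound 2 by more than the scatter. Compound 4 (`CC(C)(C)c1cccc(NC(=O)c2cc(Cl)ccc2O)c1`) has tert-butyl in place of nitro on an aromatic carbon, meta to a large group: tert-butyl in place of nitro on an aromatic carbon. The only measured replacement of nitro is trifluoromethyl, a 1.8-fold lower number from compound 1 to compound 3 (0.25 log units; within the scatter). Going by the values given here, no measured step introduces tert-butyl, so a small drop in this assay, not clearly beyond the scatter, is expected. The expected step is a 1.8-fold lower number from compound 2 to compound 4 (0.25 log units; within the scatter). Compound 4 is estimated at 11 10^-6 cm/s, with an expected range of 4.5 10^-6 cm/s to 24 10^-6 cm/s.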

Compound 4, apparent permeability: 18.7 10^-6 cm/s
Compound 4: the middle estimate sits 1.7-fold (0.23 log units) below what was measured, and the stated range covers the measured number.
By their numbers in this assay, from the lowest: compounds 3, 1, 4 and 2 (each within the scatter of the next, the first and the last beyond it).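

In this assay, tert-butyl in place of nitro on an aromatic carbon, meta to a large group, gives a 1.0-fold lower number from compound 2 to compound 4 (0.02 log units; within the scatter) and so stays within the scatter at this position. Here, 4 carbon atoms with 0 hydrogen-bond acceptors replace a group with 2 hydrogen-bond acceptors, without a step beyond the scatter. Nothing available bears on the reason for this result.

From the compounds shown here alone, whether an amine or a carboxylic acid at this position would also stay within the scatter of compound 2 remains open. The same question stands for a longer chain.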